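The compounds below may be only part of what the source reports. "The series", "measured", "known", "first", "only" and "open" are said of these compounds alone.

Of the compounds shown here, three of a shared core have been measured in a physicochemical assay for solubility, in phosphate buffer, with a stated time of 18 h; a higher number here means a more soluble compound, a lower number a less soluble compound. Compound 1 `CC(C)Cc1ncc2c(N)c(C#N)c(N)nc2n1` gives 268000 nM. Compound 2 `N#Cc1c(N)nc2nc(Cc3ccccc3)ncc2c1N` gives 13000 nM. Compound 3 `CSc1nc(C(C)(C)C)nc2nc(N)c(C#N)c(N)c12` gives 14000 nM. Among these three numbers compound 3 stands second highest: its number and that of compound 2 lie within the scatter of each other, while compound 1 sits well above it, beyond the scatter. For the measured compounds named here, the one step that is measured, a 21-fold lower number from compound 1 to compound 2 (1.31 log units; beyond the scatter), introduced a ring in place of a chain group and gave a large fall.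

Compound 4 `CC(C)(C)c1nc(-c2ccccn2)c2c(N)c(C#N)c(N)nc2n1` differs from compound 3 in one place: pyridin-2-yl in place of methylsulfanyl on an aromatic carbon. Going by the values given here, no measured pair covers this exact exchange, yet the step from compound 1 to compound 2 shows that bringing in a six-membered aromatic ring can lower the number in this assay considerably. A downward step of moderate size is therefore expected for compound 4, estimated as a 2.8-fold lower number from compound 3 to compound 4 (0.45 log units; beyond the scatter). Compound 4 is estimated at 5000 nM, within a range from 1200 nM to 20000 nM.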

Compound 4, solubility: 87000 nM
Compound 4: middle estimate off by 17-fold (1.24 log units), on the low side; the whole stated range lies below it.
By their numbers in this assay, from the lowest: compounds 2 and 3 (each within the scatter of the next); then compound 4; then compound 1.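

In this assay, pyridin-2-yl in place of methylsulfanyl on this aromatic carbon brings a 6.2-fold higher number from compound 3 to compound 4 (0.79 log units; beyond the scatter), so the entry of a six-membered aromatic ring does not lower the number in every case. The earlier fall, a 21-fold lower number from compound 1 to compound 2 (1.31 log units; beyond the scatter), came with phenyl in place of isopropyl on a saturated chain carbon, a different place and a different exchange, so the two steps set no common rule for such a ring. Nothing available offers a reason for the higher number of compound 4.

The compounds shown leave open whether a plain phenyl on this aromatic carbon would behave as pyridin-2-yl does, and so what part the ring nitrogen plays. They also leave open how an amine or a carboxylic acid at this place would read.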